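Permeability notes: acyl group swap from compound 2 to compound 3

This account rests on a few compounds, and the source may have more. Where it says the series, first, only, none or still open, it means among the compounds named here.

Among the compounds with values here, compound 2 `Cn1cc(-c2nc3c(-c4ccc(CNC(=O)c5cc6c(s5)CCCC6)c(F)c4)ccnc3[nH]2)cn1` sits lowest of the two numbers so far: in an ADME assay on Caco-2 cells (Homo sapiens) for permeability, in the apical to basolateral direction (on this read-out higher numbers stand for higher permeability and lower numbers for lower permeability), compound 2 gives 0.6 10^-6 cm/s, while compound 1 `Cn1cc(-c2nc3c(-c4ccc(CNC(=O)c5cc(C(C)(C)C)no5)c(F)c4)ccnc3[nH]2)cn1` gives 3 10^-6 cm/s. Within the data shown here, the one measured step, a 5.0-fold lower number from compound 1 to compound 2 (0.70 log units; beyond the scatter), is the only guide and also sits on a carbonyl carbon. Compound 3 `CC1CC2(C1)CN(C(=O)NCc1ccc(-c3ccnc4[nH]c(-c5cnn(C)c5)nc34)cc1F)C2` carries the change (a group of 8 heavy atoms (7 carbon, 1 nitrogen; one four-membered non-aromatic ring of carbon only, one four-membered non-aromatic ring with 1 hetero atom) in place of a group of 9 heavy atoms (8 carbon, 1 sulfur; one five-membered aromatic ring with 1 hetero atom, one six-membered non-aromatic ring of carbon only), on a carbonyl carbon). A step of comparable size is expected, most likely upward, though the direction rests on a single comparison. Compound 3 is expected to read about 1.5 10^-6 cm/s, within 0.4 10^-6 cm/s to 5 10^-6 cm/s, an expected 2.5-fold higher number from compound 2 to compound 3 (0.40 log units; beyond the scatter).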

Compound 3, apparent permeability: 8 10^-6 cm/s
Compound 3: the middle estimate sits 5.3-fold (0.73 log units) below what was measured; the whole stated range lies below it.
By their numbers in this assay, from the lowest: compound 2; then compound 1; then compound 3.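

In this assay, within the data shown here, this carbonyl-carbon position spans a wider range than the one earlier step showed: a 13-fold higher number from compound 2 to compound 3 (1.12 log units; beyond the scatter), and a 2.7-fold higher number from compound 1 to compound 3 (0.43 log units; beyond the scatter). Of the three groups on this carbon, the one with two four-membered non-aromatic rings gives the highest number, so a five-membered aromatic ring is not required here for a higher read-out.

Nothing available bears on the reason for these steps. On these data alone, it remains open whether a piperidine or a morpholine on the same carbonyl carbon would hold the number of compound 3 or lose it.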